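The source may hold more compounds than are shown below. What is called first, only, known or untested is meant among the compounds shown, and "the series" means these compounds.

Working notes on the series. Compound 1 `CCOC(=O)c1c(C)nc(-c2ccc(C#N)cc2)n1OC` in a functional assay on a cell-free system (plasma, Oryctolagus cuniculus) for inhibition, with stated times of 5 min, 1 min and 6 min (a lower number here means a stronger inhibitor, a higher number a weaker inhibitor), gives 13400 nM. Compound 2 `CCOC(=O)c1c(C)nc(-c2ccccc2)n1OC` reaches only the limit of this assay, > 30000 nM. For the measured compounds named here, the single measured step, an at least 2.2-fold higher number from compound 1 to compound 2 (0.35 log units; beyond the scatter), concerns hydrogen in place of cyano on an aromatic carbon. Compound 3 `CCOC(=O)c1c(C)nc(-c2cccc(C#N)c2)n1OCCC(=O)O` likewise reaches only the limit of this assay, > 30000 nM. Compound 3 therefore stands at the limit of > 30000 nM in this assay, at which 2 of the 3 values shown sit, and no number is known for it.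

Compound 4 `CCOC(=O)c1c(C)nc(-c2cccc(C#N)c2)n1OCc1ccc(C(=O)OC)cc1` differs from compound 3 by 4-(methoxycarbonyl)phenyl in place of carboxymethyl on a saturated chain carbon bound to an oxygen on an aromatic ring. Going by the values given here, no measured step touches a saturated chain carbon bound to an oxygen on an aromatic ring; the one step measured bears on the aromatic ring alone and gives no direct guidance for this change, and the starting point is itself a limit. The expectation is open: a number near the limit or a second limit. Compound 4 is estimated at 15000 nM, within an expected range of 3000 nM to 60000 nM. The step this estimate implies, an at least 2.0-fold lower number from compound 3 to compound 4 (0.30 log units; that floor lies within the scatter), is an expectation only, without a measured step to fix its direction.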

Compound 4, half-maximal inhibitory concentration: 9470 nM
Compound 4: the middle estimate sits 1.6-fold (0.20 log units) above what was measured; measured number inside the range.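

In this assay, for the compounds shown here, 4-(methoxycarbonyl)phenyl in place of carboxymethyl gives an at least 3.1-fold lower number from compound 3 to compound 4 (0.50 log units; beyond the scatter), the first measured step at the saturated chain carbon bound to an oxygen on an aromatic ring. Going by these compounds alone, the earlier step bore on the aromatic ring alone, so this is the first sign that the group carried at this place also moves the number, here with a ring entering and the hydrogen-bond donor leaving. The step is only a floor, as its starting point is a limit and not a number: the limit of > 30000 nM in this assay, at which 2 of the 4 values shown sit.

Within the data shown here, the single swap changes several things at once, so it remains open whether the aromatic ring or the methyl ester on it carries the step. As far as these compounds go, a plain phenyl or an amine at this place would separate the two, and the direction of either change is unknown.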